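Aryl substituent variation on the thiosemicarbazone series

The compounds below may be only part of what the source reports. "The series", "measured", "known", "first", "only" and "open" are said of these compounds alone.

Compound 3 `COc1ccc(/C=N\NC(=S)NC(C)(C)CCC[C@](C)(O)[C@@H]2CC=C(C)CC2)cc1` gives the lowest of the three numbers measured in a functional assay on UACC-62 cells (Homo sapiens) for cytotoxicity, read by sulforhodamine B assay (on this read-out lower numbers stand for stronger inhibition of growth and higher numbers for weaker inhibition of growth), 7420 nM, yet its steps to the other two stay within the scatter: compound 1 `CC1=CC[C@@H]([C@@](C)(O)CCCC(C)(C)NC(=S)N/N=C\c2ccccc2)CC1` gives 12700 nM and compound 2 `CC1=CC[C@@H]([C@@](C)(O)CCCC(C)(C)NC(=S)N/N=C\c2ccc(C)cc2)CC1` gives 11600 nM. Compound 4 `CC1=CC[C@@H]([C@@](C)(O)CCCC(C)(C)NC(=S)N/N=C\c2ccc(O)cc2)CC1` differs from compound 3 by hydrogen in place of methyl on an oxygen on an aromatic ring. The measured steps that bear on this all sit on the same aromatic position: a 1.7-fold lower number from compound 1 to compound 3 (0.23 log units; within the scatter) and a 1.6-fold lower number from compound 2 to compound 3 (0.19 log units; within the scatter), alongside a 1.1-fold lower number from compound 1 to compound 2 (0.04 log units; within the scatter). Every one of them lies within the scatter, so no step beyond the scatter is expected from this further change at the same position. The step is expected to read a 1.1-fold higher number from compound 3 to compound 4 (0.06 log units; within the scatter). Compound 4 is estimated at 8500 nM in this assay, with a range from 4000 nM to 18000 nM.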

Compound 4, concentration for 50% growth inhibition: 8870 nM
Beside the measured number, compound 4's estimate is 1.0-fold (0.02 log units) below it; low and high end bracket the measured number.
By their numbers in this assay, from the lowest: compounds 3, 4, 2 and 1 (each within the scatter of the next).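

In this assay the swap of methyl for hydrogen on the oxygen gives a 1.2-fold higher number from compound 3 to compound 4 (0.08 log units; within the scatter) and does not separate 4-hydroxyphenyl from 4-methoxyphenyl. Hydroxy also fails to separate from methyl or hydrogen on the aromatic carbon, with a 1.3-fold lower number from compound 2 to compound 4 (0.12 log units; within the scatter) and a 1.4-fold lower number from compound 1 to compound 4 (0.16 log units; within the scatter) and so all four groups now sit within the scatter of one another at this place. No evidence bears on this result.

From the compounds shown here alone, whether an amine or a carboxylic acid on this aromatic carbon would give a step beyond the scatter remains open. So does the effect of a longer chain on the oxygen.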